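The source may hold more compounds than are shown below. What is called first, only, known or untested is meant among the compounds shown, and "the series" means these compounds.

Measured so far:
Compound 1, `CNCc1cn(S(=O)(=O)c2cccs2)c(-c2cccnc2F)c1F`, in a physicochemical assay for lipophilicity, read by HPLC, at pH 7.4 (on this read-out higher numbers stand for higher lipophilicity and lower numbers for lower lipophilicity), gives 0.54.
Compound 2, `CNCc1cn(S(=O)(=O)c2ccco2)c(-c2cccnc2F)c1F`, in this assay gives 0.2.
Compound 3, `CNCc1cn(S(=O)(=O)c2ccccn2)c(-c2cccnc2F)c1F`, in this assay gives 0.44.

Compound 2 stands lowest of the three numbers in this assay. Its nearest neighbour is compound 3: a number 0.24 log units higher from compound 2 to compound 3 (within the scatter). Its furthest is compound 1: a number 0.34 log units lower from compound 1 to compound 2 (beyond the scatter).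

Unmeasured compound 4, `CNCc1cn(S(=O)(=O)c2cncc(Cl)c2)c(-c2cccnc2F)c1F`, differs from compound 2 in one place: 5-chloropyridin-3-yl in place of furan-2-yl on a sulfonyl sulfur. The measured steps that bear on this are the exchanges of the group on the sulfonyl sulfur: a number 0.24 log units higher from compound 2 to compound 3 (within the scatter) and a number 0.10 log units lower from compound 1 to compound 3 (within the scatter), both within the scatter, and a number 0.34 log units lower from compound 1 to compound 2 (beyond the scatter), a modest change. A six-membered aromatic ring with one hetero atom entering for the furan-2-yl thus points upward by roughly the step seen to compound 3; the chlorine on the entering ring is not covered by any measured pair, so the range must be set wide. The expected step is a number 0.80 log units higher from compound 2 to compound 4 (beyond the scatter), upward and beyond the scatter. Compound 4 is estimated at 1, between 0.6 and 1.4.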

Compound 4, distribution coefficient: 1.44
Compound 4: the middle estimate sits 0.44 log units below what was measured; the measured number lies above the stated range.
By their numbers in this assay, from the lowest: compounds 2, 3 and 1 (each within the scatter of the next, the first and the last beyond it); then compound 4.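

This position carries far larger shifts in this assay than the earlier exchanges showed: the step among the earlier groups that lies beyond the scatter (a number 0.34 log units lower from compound 1 to compound 2 (beyond the scatter)) is smaller than each of the new steps (a number 1.24 log units higher from compound 2 to compound 4 (beyond the scatter); a number 0.90 log units higher from compound 1 to compound 4 (beyond the scatter)). Ring type alone does not set the number, since pyridin-2-yl and 5-chloropyridin-3-yl each bring a six-membered aromatic ring with 1 hetero atom and still differ widely (a number 1.00 log units higher from compound 3 to compound 4 (beyond the scatter)). No measurement at hand gives a cause for the size of these steps.

From the compounds shown here alone, compound 4 differs from compound 3 in both the chlorine and the point of attachment of the ring, so the share of each stays open. An unsubstituted pyridin-3-yl, or a pyridin-3-yl with a methyl or a nitrile in place of the chlorine, would separate the two.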